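Adding fluoro to compound 3

The source may report more compounds than this note shows. Statements on the series, on what has been measured and on what is new or still open speak of the compounds shown alone.

Going by the values given here, in an ADME assay for permeability, using PAMPA, at pH 7.4 (a higher number here means that the compound crosses the layer faster, a lower number that the compound crosses the layer more slowly), compound 3 `CCCCC#Cc1c(C)[nH]c2ccccc2c1=O` gives 2140 10^-6 cm/s, the highest of the three numbers so far. Compound 1 `Cc1[nH]c2ccccc2c(=O)c1C1CCCCC1` gives 230 10^-6 cm/s, and compound 2 `Cc1[nH]c2ccc(F)cc2c(=O)c1Br` gives 18.3 10^-6 cm/s. Compound 4 `CCCCC#Cc1c(C)[nH]c2ccc(F)cc2c1=O` differs from compound 3 by fluoro in place of hydrogen on an aromatic carbon. Among the compounds with values here, the only measured step, a 9.3-fold higher number from compound 1 to compound 3 (0.97 log units; beyond the scatter), concerns hex-1-yn-1-yl in place of cyclohexyl and does not test fluoro. Within the data shown here, compound 2 also carries fluoro but lacks the hex-1-yn-1-yl group, so no measured pair isolates this change. No shift beyond the scatter is therefore expected in this assay. The expected step is a 1.1-fold lower number from compound 3 to compound 4 (0.05 log units; within the scatter). For compound 4 the estimated value is 1900 10^-6 cm/s, with an expected range of 800 10^-6 cm/s to 4000 10^-6 cm/s.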

Compound 4, apparent permeability: 495 10^-6 cm/s
Compound 4: middle estimate off by 3.8-fold (0.58 log units), on the high side; measured number outside the range, below it.
By their numbers in this assay, from the lowest: compound 2; then compound 1; then compound 4; then compound 3.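

Fluoro in place of hydrogen on an aromatic carbon is not neutral in this assay: with hex-1-yn-1-yl held fixed, the change gives a 4.3-fold lower number from compound 3 to compound 4 (0.64 log units; beyond the scatter). With fluoro held fixed, hex-1-yn-1-yl in place of bromo gives a 27-fold higher number from compound 2 to compound 4 (1.43 log units; beyond the scatter), so the gain from hex-1-yn-1-yl survives on the fluoro compounds, at least in this one pair. No measurement shown explains the fluoro step. Still open, on these data alone, is whether the fluoro step carries over when cyclohexyl replaces hex-1-yn-1-yl. Also open, as far as these compounds go, is whether chloro or methoxy on the same aromatic carbon moves the number as fluoro does.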